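Swapping phenyl for hydroxymethyl on compound 3

This account rests on a few compounds, and the source may have more. Where it says the series, first, only, none or still open, it means among the compounds named here.

In a functional assay on the whole organism with Rattus norvegicus as the target (on this read-out higher numbers stand for an effect only at larger amounts of compound and lower numbers for an effect already at smaller amounts), compound 3 `O=C(O)C(=O)Nc1nc(-c2cc(-c3ccccc3)on2)cs1` gives 0.23 mg/kg as the lowest number of the three measured compounds. Compound 2 `Cc1cc(-c2csc(NC(=O)C(=O)O)n2)no1` gives 1.7 mg/kg and compound 1 `CCOCCOC(=O)C(=O)Nc1nc(-c2cc(CO)on2)cs1` gives 1.8 mg/kg in the same read-out.

Compound 4 `O=C(O)C(=O)Nc1nc(-c2cc(CO)on2)cs1` carries hydroxymethyl in place of phenyl on an aromatic carbon. Among the compounds with values here, the one measured step that bears on this change is a 7.4-fold lower number from compound 2 to compound 3 (0.87 log units; beyond the scatter) with phenyl in place of methyl on an aromatic carbon. That step is modest but beyond the scatter, and removing phenyl from compound 3 should therefore raise the number by a similar size. Compound 1 supports this: it already carries hydroxymethyl, as an ester and not the free acid, and stands at 1.8 mg/kg in this assay. Within the data shown here, no measurement yet separates hydroxymethyl from methyl on the free acid.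

For compound 4 the estimate is 1.6 mg/kg with an expected range of 0.6 mg/kg to 4 mg/kg on this read-out.

The expected change is a 7.0-fold higher number from compound 3 to compound 4 (0.84 log units; beyond the scatter) as estimated here.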

Compound 4, dose for half-maximal effect: > 100 mg/kg
Compound 4: no number, only a limit (the forecaster's own chance of this, stated with the estimate: 3%); at least 62-fold (1.79 log units) between middle value and limit.
By their numbers in this assay, from the lowest: compound 3; then compounds 2 and 1 (each within the scatter of the next). At a limit, above all of these: compound 4.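

In this assay compound 4 gives > 100 mg/kg, which is a limit of the assay and not a number: the limit of > 100 mg/kg in this assay, at which 1 of the 4 values shown sits.

On the free acid the change on this aromatic carbon is large in both directions of comparison, with an at least 430-fold higher number from compound 3 to compound 4 (2.63 log units; beyond the scatter) for hydroxymethyl in place of phenyl and an at least 58-fold higher number from compound 2 to compound 4 (1.76 log units; beyond the scatter) for hydroxy in place of hydrogen on the chain carbon, so the step is not tied to the loss of phenyl and the added hydroxy alone is enough. Hydroxymethyl does not decide the result on its own, since the ester form keeps a number, with an at least 55-fold higher number from compound 1 to compound 4 (1.74 log units; beyond the scatter) for hydrogen in place of 2-ethoxyethyl.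

Open, on these data alone, is whether a methoxymethyl or aminomethyl group on this aromatic carbon of the free acid gives a number in this assay. Also open, as far as these compounds go, is whether the 2-ethoxyethyl ester changes the number for the methyl and phenyl acids as it does for hydroxymethyl.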